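Hexyl in place of dec-1-yn-1-yl on the sulfonyl aryl ring

This account rests on a few compounds, and the source may have more. Where it says the series, first, only, none or still open, it means among the compounds named here.

Compounds measured in a functional assay on A-375 cells (Homo sapiens) for antiproliferative activity, read by trypan blue exclusion, with a stated time of 48 h, tested at 1 uM; a lower number here means a stronger effect, a higher number a weaker effect of the compound at the concentration tested:
compound 1 `CC(=O)Nc1nc(-c2cccc(NS(=O)(=O)c3ccc(Br)cc3)c2)cs1`: "not active" (no number reported)
compound 2 `CC(=O)Nc1nc(-c2cccc(NS(=O)(=O)c3ccc(C#CC4CCCCC4)cc3)c2)cs1`: 52.3%
compound 3 `CCCCCCCCC#Cc1ccc(S(=O)(=O)Nc2cccc(-c3csc(NC(C)=O)n3)c2)cc1`: 39.6%

Among the compounds with a number in this assay, compound 3 gives the lowest value; its nearest neighbour is compound 2, and the change a number 12.7 percentage points lower from compound 2 to compound 3 (beyond the scatter) is beyond the scatter. Compound 1, which carries a bromine at the same place, was reported as not active in this assay, so it adds no number to compare against.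

Compound 4 `CCCCCCc1ccc(S(=O)(=O)Nc2cccc(-c3csc(NC(C)=O)n3)c2)cc1` is the next step: hexyl in place of dec-1-yn-1-yl on an aromatic carbon. Within the data shown here, only one measured step touches this part of the molecule, the step from compound 2 to compound 3, in which a longer chain on the triple-bonded carbon gave a modestly lower number. Compound 4 moves the other way, to a shorter group and with the triple bond gone, while the inactive compound 1 shows that a small group at this place gives no measurable effect. The value for compound 4 is therefore expected to rise, by about a number 12.4 percentage points higher from compound 3 to compound 4 (beyond the scatter), and compound 4 is estimated at 52% within a range of 35% to 75%.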

Compound 4, a percentage reported as activity, at one concentration (the size of the read-out at that concentration, not a potency): 49.9%
Compound 4: the middle estimate sits 2.1 percentage points above what was measured, and the stated range covers the measured number.
By their numbers in this assay, from the lowest: compound 3; then compounds 4 and 2 (each within the scatter of the next).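

The triple bond is not needed for a measurable effect at this place on the ring: in this assay compound 4, with its plain hexyl chain, gives a number, whereas compound 1, with bromine, is reported as "not active" (no number reported). Hexyl and 2-cyclohexylethynyl cannot be told apart here, with a number 2.4 percentage points lower from compound 2 to compound 4 (within the scatter), but dec-1-yn-1-yl keeps an edge over hexyl, with a number 10.3 percentage points higher from compound 3 to compound 4 (beyond the scatter). No measurement shown explains either step, and this change shortens the chain and removes the triple bond together.

The compounds shown leave open whether chain length or the triple bond accounts for the step between dec-1-yn-1-yl and hexyl, a question that a decyl chain or a hex-1-yn-1-yl group would address. They also leave open how an amine or a carboxylic acid at the end of the chain would read out.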